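A few compounds are considered here, and "the series" means these few. Any claim that something is new, unique, unknown or untested is made for them only; others in the source may bear on it.

Measured in a functional assay on A549 cells (Homo sapiens) for inhibition, read by sulforhodamine B assay, with a stated time of 48 h; on this read-out lower numbers stand for stronger inhibition of growth and higher numbers for weaker inhibition of growth:
Compound 1 `CC(C)c1cc(C(=O)N(C)c2ccc(NC(=O)CCCCCCCCC(=O)NO)cc2)c(O)cc1O`: 1080 nM
Compound 2 `CC(C)c1cc(C(=O)N(c2ccc(NC(=O)CCCCCCC(=O)NO)cc2)C(C)C)c(O)cc1O`: > 10000 nM

Among the compounds with values here, only two compounds have been measured so far, and no single-place step connects them. Compound 2 stands at > 10000 nM, which is a limit of this assay and not a number. Its place on the scale is therefore known only from that limit.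

Compound 3 `CC(C)c1cc(C(=O)N(C)c2ccc(NC(=O)CCCCCCC(=O)NO)cc2)c(O)cc1O` has yet to be measured. It differs from compound 2 in one place, with methyl in place of isopropyl on an amide-type nitrogen.

Within the data shown here, the only guide is compound 1, which also carries methyl on that amide-type nitrogen and gives 1080 nM. With that value in view, compound 3 is expected to inhibit growth more strongly than the limit of compound 2 indicates, by a step beyond the usual scatter. The estimated change is an at least 4.0-fold lower number from compound 2 to compound 3 (0.60 log units; beyond the scatter). This rests on very few data, so the expected range is wide. The estimated value for compound 3 is 2500 nM, with an expected range from 700 nM to 9000 nM.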

Compound 3, concentration for 50% growth inhibition: 770 nM
The estimate for compound 3 lay 3.2-fold (0.51 log units) above the measured number; low and high end bracket the measured number.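

In this assay, putting methyl in place of isopropyl on an amide-type nitrogen, with the other neighbours of that nitrogen an aromatic carbon and a carbonyl carbon, gives an at least 12-fold lower number from compound 2 to compound 3 (1.11 log units; beyond the scatter). Compounds 1 and 2 differ in more than one place and could not isolate this change, so this is the only direct reading of the position among the compounds shown, and it points to a large loss of growth inhibition with isopropyl on that nitrogen. Compound 2 stands at a limit of the assay and not at a number, so the true size of the step remains unknown: the limit of > 10000 nM in this assay, at which 1 of the 3 values shown sits.

The second step holds methyl on that nitrogen and changes only the chain, with hydroxycarbamoyl in place of 2-(hydroxycarbamoyl)ethyl on a saturated chain carbon, and it gives a 1.4-fold lower number from compound 1 to compound 3 (0.15 log units; within the scatter), so these two chain lengths cannot be told apart in this assay.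

How ethyl or a plain hydrogen on that nitrogen would read remains open, so the compounds shown do not reveal how the values change between methyl and isopropyl. Also open, from the compounds shown here alone, is whether isopropyl has a similar impact when paired with the longer chain of compound 1, and how a shorter chain would read.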